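Chloro Added to a Fused Core: Expected Growth Inhibition

A few compounds are considered here, and "the series" means these few. Any claim that something is new, unique, unknown or untested is made for them only; others in the source may bear on it.

Measured compounds:
compound 1, `ClCc1ccccc1Cn1cnc2c(Cl)nc(Cl)nc21`: 3020 nM
compound 2, `ClCc1ccccc1Cn1cnc2c(Cl)ncnc21`: 4670 nM
compound 3, `ClCc1ccccc1Cn1cnc2ncnc(Cl)c21`: 4460 nM

Of the compounds shown here, three have been tested in a functional assay on NCI/ADR-RES cells (Homo sapiens) for cytotoxicity, read by sulforhodamine B assay, with a stated time of 48 h; on this read-out lower numbers stand for stronger inhibition of growth and higher numbers for weaker inhibition of growth. Compound 1 and compound 2 share a core and differ in one place: chloro in place of hydrogen on an aromatic carbon. The step this change made is a 1.5-fold lower number from compound 2 to compound 1 (0.19 log units; within the scatter), so on this read-out the two lie within the usual scatter of each other. Compound 3 is built from the same atoms as compound 2, joined differently; the difference between the two cores is not broken down here. In this assay compound 3 gives 4460 nM, and the values of compound 2 and compound 3 lie within the scatter of one another, so nothing can be said about their order.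

Compound 4 `ClCc1ccccc1Cn1cnc2nc(Cl)nc(Cl)c21` has not yet been measured. It stands to compound 3 as compound 1 stands to compound 2: chloro in place of hydrogen on an aromatic carbon. The place described around the entering group is the same in words for both pairs, so the change is the same one, made on the other core. It was seen once among the measured compounds, and that one occurrence gave a step that was within the scatter. On that basis compound 4 is expected to show a step of about a 1.5-fold lower number from compound 3 to compound 4 (0.17 log units; within the scatter) in this assay, because the earlier step was a 1.5-fold lower number from compound 2 to compound 1 (0.19 log units; within the scatter). For the measured compounds named here, the estimate for compound 4 in this assay is 3000 nM, expected to fall between 1500 nM and 6500 nM, since only one prior step supports it and the second core is untested for this change.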

Compound 4, concentration for total growth inhibition: 5010 nM
The estimate for compound 4 lay 1.7-fold (0.22 log units) below the measured number; measured number inside the range.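

In this assay, chloro in place of hydrogen on an aromatic carbon gave a 1.1-fold higher number from compound 3 to compound 4 (0.05 log units; within the scatter), so compound 3 and compound 4 cannot be told apart on this read-out. Set beside the earlier occurrence of this change, the new step does not differ from it: the same change on two cores in this assay, a 1.5-fold lower number (0.19 log units; within the scatter) from compound 2 to compound 1 and a 1.1-fold higher number (0.05 log units; within the scatter) from compound 3 to compound 4, 1.7-fold (0.24 log units) apart, within the scatter of two such steps. For the compounds shown here, this shows that, on both cores, the change gave a step too small to read, and the two cores do not separate in how they take it; it does not show that chloro has a real effect on either core, nor that the same result would hold on any further core, as only two pairs are available.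

The compounds shown carry only chloro or hydrogen at the places examined, so it remains open whether an amine, a methoxy group or a longer chain there would give a step beyond the scatter. The chloromethyl group is also the same in all four compounds, which leaves open how replacing it with, for example, a hydroxymethyl group or a plain methyl group would read in this assay.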